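Benzyl to 4-methoxyphenyl on the shared core

The source may hold more compounds than are shown below. What is called first, only, known or untested is meant among the compounds shown, and "the series" means these compounds.

For the measured compounds named here, compound 2 `CCOC(=O)CNc1nc(NCc2ccccc2)ncc1[N+](=O)[O-]` is the only member of the pair with a numeric read-out: in a functional assay on A549 cells (Homo sapiens) for antiproliferative activity, read by MTT assay, with a stated time of 48 h (on this read-out lower numbers stand for stronger inhibition and higher numbers for weaker inhibition), compound 2 gives 74400 nM. Compound 1 `CCOC(=O)CNc1nc(Nc2ccccc2)ncc1[N+](=O)[O-]` reached only a limit, and in this assay compound 1 gives > 100000 nM. Going by the values given here, the single measured step, an at least 1.3-fold lower number from compound 1 to compound 2 (0.12 log units; that floor lies within the scatter), is the only comparison available, and it sits within scatter.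

Compound 3 `CCOC(=O)CNc1nc(Nc2ccc(OC)cc2)ncc1[N+](=O)[O-]` differs from compound 2 by 4-methoxyphenyl in place of benzyl on a nitrogen on an aromatic ring. Among the compounds with values here, the change runs back toward the phenyl of compound 1 and adds a methoxy group on the aromatic ring, for which no measured step exists. Since compound 1 stands at the limit of > 100000 nM in this assay, at which 1 of the 2 values shown sits, the direction expected for compound 3 is a higher number, possibly again only a limit rather than a value, and the size cannot be set from one within-scatter step.

Compound 3 is therefore expected to give 110000 nM, within 45000 nM to 270000 nM, in this assay. That estimate means an expected step of a 1.5-fold higher number from compound 2 to compound 3 (0.17 log units; within the scatter).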

Compound 3, half-maximal inhibitory concentration: > 100000 nM
Compound 3 ended at the assay's limit; the forecaster's own chance of this, stated with the estimate: 55%; the middle value lies beyond the limit too.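

In this assay, 4-methoxyphenyl in place of benzyl on a nitrogen on an aromatic ring gives an at least 1.3-fold higher number from compound 2 to compound 3 (0.12 log units; that floor lies within the scatter), so no real loss can be claimed from this change. For the compounds shown here, on the shared core, benzyl in compound 2 is now the only group with a numeric read-out, while phenyl in compound 1 and 4-methoxyphenyl in compound 3 both end at a limit, leaving this position with little readable range: the limit of > 100000 nM in this assay, at which 2 of the 3 values shown sit. The step from compound 1 to compound 3 cannot be read, so methoxy in place of hydrogen on the aromatic ring has no measurable size here.

Still open, as far as these compounds go, is whether a longer chain carrying the phenyl ring on that nitrogen, or an amine on the aromatic ring, would move the read-out beyond the scatter from compound 2.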